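The compounds below may be only part of what the source reports. "The series", "measured", "known", "first", "only" and "open" are said of these compounds alone.

Measured so far:
compound 1 `CCN(CC)CCNC(=O)C1CC(C(CC)(CC)c2ccc(C#CC(C)(C)O)c(C)c2)=CN1CC`, 56.3%
compound 2 `CCCC(O)(C#Cc1ccc(C(CC)(CC)C2=CCC(C(=O)NCCN(CC)CC)N2CC)cc1C)CCC`, 52.1%

Both compounds were tested in an assay on isolated protein for binding affinity to vitamin D3 receptor (Homo sapiens), read by fluorescence polarization, tested at 1 uM; a higher number here means more inhibition at the concentration tested (going by the name of the read-out), a lower number less inhibition. Compound 1 gives 56.3% and compound 2 gives 52.1%; the two numbers lie within the scatter of each other, so neither can be set above the other. Compound 3 `C#Cc1ccc(C(CC)(CC)C2=CN(CC)C(C(=O)NCCN(CC)CC)C2)cc1C` has not been measured. It differs from compound 1 in one place: hydrogen in place of 1-hydroxy-1-methylethyl on a triple-bonded carbon. Among the compounds with values here, no step between two measured compounds shows what such a change does here, so the expectation rests on the values of compound 1 alone. A moderate drop beyond the scatter is expected, a number 16.3 percentage points lower from compound 1 to compound 3 (beyond the scatter). Compound 3 is estimated at 40%, between 20% and 58%.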

Compound 3, a percentage reported as inhibition, at one concentration (the size of the read-out at that concentration, not a potency): "not active" (no number reported)
Compound 3: no number reported, and the estimate cannot be compared.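

Within the data shown here, compound 3 is reported as "not active" with no number in this assay, so no step from compound 1 can be read. The compounds shown leave open how far replacing 1-hydroxy-1-methylethyl with hydrogen changes the read-out. Nothing shown accounts for this result.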